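The source may report more compounds than this note shows. Statements on the series, on what has been measured and on what is new or still open speak of the compounds shown alone.

In a functional assay on PC-3 cells (Homo sapiens) for antiproliferative activity, read by MTT assay, with a stated time of 72 h (on this read-out higher numbers stand for weaker inhibition and lower numbers for stronger inhibition), compound 1 (`CCN(CC)CCCNC(=O)c1ccc(C(CC)(CC)c2ccc(C#CC(O)(CC)CC)c(C)c2)n1CC`) gives 8500 nM. Compound 2 (`CCn1c(C(=O)NCc2ccc(OC)cc2)ccc1C(CC)(CC)c1ccc(C#CC(O)(CC)CC)c(C)c1`) reads > 50000 nM, which is a limit of the assay and not a number. For the measured compounds named here, compound 3 (`CCn1c(C(=O)NCC(=O)O)ccc1C(CC)(CC)c1ccc(C#CC(O)(CC)CC)c(C)c1`) gives 2250 nM, the lowest value so far, and compound 1 is its nearest neighbour.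

Compound 4 (`CCn1c(C(=O)N[C@H](C(=O)O)C(C)C)ccc1C(CC)(CC)c1ccc(C#CC(O)(CC)CC)c(C)c1`) carries isopropyl in place of hydrogen on a saturated chain carbon bound to an amide-type nitrogen and a carbonyl carbon.

The three measured steps all lie in this amide side chain, but each swaps the end group: a 3.8-fold lower number from compound 1 to compound 3 (0.58 log units; beyond the scatter), an at least 22-fold lower number from compound 2 to compound 3 (1.34 log units; beyond the scatter) and an at least 5.8-fold higher number from compound 1 to compound 2 (0.76 log units; beyond the scatter). The first is modest, the second large and the third at least modest. The large step brings in the carboxy group, which compound 4 keeps, so its size does not carry over. Going by the values given here, no measured compound tests a substituent on this chain carbon, so the expectation remains loose.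

Compound 4 retains the carboxy of compound 3 at 2250 nM, so a step beyond the scatter is not expected in this assay, with only a slight lean towards a higher number. The expected step is a 1.3-fold higher number from compound 3 to compound 4 (0.12 log units; within the scatter). For compound 4 the estimate is 3000 nM, with an expected range of 800 nM to 11000 nM.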

Compound 4, half-maximal inhibitory concentration: 5000 nM
Beside the measured number, compound 4's estimate is 1.7-fold (0.22 log units) below it; the measured number falls inside the stated range.
By their numbers in this assay, from the lowest: compound 3; then compounds 4 and 1 (each within the scatter of the next). At a limit, above all of these: compound 2.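

In this assay, the compounds now include a substituent on the saturated chain carbon bound to an amide-type nitrogen and a carbonyl carbon, and isopropyl in place of hydrogen there gives a 2.2-fold higher number from compound 3 to compound 4 (0.35 log units; beyond the scatter); with the carboxy kept, this position therefore responds to substitution, though the step is only modest. With the isopropyl in place, the 1-carboxy-2-methylpropyl group on the amide-type nitrogen gives an at least 10-fold lower number from compound 2 to compound 4 (1.00 log units; beyond the scatter) when it replaces 4-methoxybenzyl, while replacing 3-(diethylamino)propyl gives a 1.7-fold lower number from compound 1 to compound 4 (0.23 log units; within the scatter), so the isopropyl brings compound 4 level, within the scatter, with the amine-bearing compound 1. The reading of compound 2, which anchors the first of these two steps, is a limit of the assay and not a number: the limit of > 50000 nM in this assay, at which 1 of the 4 values shown sits.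

Whether the step at this chain carbon tracks the size of the group remains open, since methyl, isobutyl and benzyl at this carbon do not appear among the compounds shown, nor does the opposite configuration of the isopropyl-bearing carbon. Also open, as far as these compounds go, is whether the carboxy itself is required on the substituted chain, which a methyl ester or a primary amide in its place would test.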